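A few compounds are considered here, and "the series" means these few. Any claim that something is new, unique, unknown or untested is made for them only; others in the source may bear on it.

Of the compounds shown here, two have been measured in a functional assay on A549 cells (Homo sapiens) for cytotoxicity, read by MTT assay, with a stated time of 4 days; on this read-out lower numbers stand for stronger inhibition and higher numbers for weaker inhibition. Compound 1 `C=C1C(=O)[C@]23C[C@@]1(O)CC[C@H]2c1ccc(OS(=O)(=O)c2ccc(C)cc2)c(C)c1[C@@H]3Cn1cc(-c2ccc(Br)cc2)nn1` gives 1630 nM. Compound 2 `C=C1C(=O)[C@]23C[C@@]1(O)CC[C@H]2c1ccc(O)c(C)c1[C@@H]3Cn1cc(-c2ccc(F)cc2)nn1` gives 940 nM, the lower of the two numbers, but the gap to compound 1 lies within the scatter, so no order between them can be read. Compound 3 `C=C1C(=O)[C@]23C[C@@]1(O)CC[C@H]2c1ccc(OS(=O)(=O)c2ccc(C)cc2)c(C)c1[C@@H]3Cn1cc(-c2ccc(F)cc2)nn1` carries the change ((4-methylphenyl)sulfonyl in place of hydrogen on an oxygen on an aromatic ring), (4-methylphenyl)sulfonyl in place of hydrogen on an oxygen on an aromatic ring, and otherwise matches compound 2. Within the data shown here, no step between measured compounds isolates this change; compound 1 carries the same ((4-methylphenyl)sulfonyl)oxy group but differs from compound 2 in a second place as well, and its value sits within the scatter of that of compound 2. The expected step in this assay is a 1.5-fold higher number from compound 2 to compound 3 (0.17 log units; within the scatter), small, toward a higher number if anything. Compound 3 is estimated at 1400 nM, with a range from 600 nM to 3300 nM.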

Compound 3, half-maximal inhibitory concentration: 1950 nM
The estimate for compound 3 lay 1.4-fold (0.14 log units) below the measured number; measured number inside the range.
By their numbers in this assay, from the lowest: compounds 2, 1 and 3 (each within the scatter of the next, the first and the last beyond it).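

In this assay, the change from hydroxy to ((4-methylphenyl)sulfonyl)oxy on the aromatic ring now has an isolated reading: a 2.1-fold higher number from compound 2 to compound 3 (0.32 log units; beyond the scatter). The free hydroxy is therefore modestly favoured over this sulfonate at this position, though the step lies only just beyond the scatter. With the ((4-methylphenyl)sulfonyl)oxy group held constant, fluoro in place of bromo on an aromatic carbon gives a 1.2-fold higher number from compound 1 to compound 3 (0.08 log units; within the scatter), so this pair separates neither halogen from the other. No measurement shown gives a reason for the sulfonate step.

Going by these compounds, it remains open whether a methyl ether or an acetyl ester on the same oxygen would give a step of similar size, or whether the step is specific to the (4-methylphenyl)sulfonyl group. Also open, on these data alone, is how a methanesulfonyl group would read at this position.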